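The source may hold more compounds than are shown below. What is called first, only, known or untested is meant among the compounds shown, and "the series" means these compounds.

Compound 1 `COc1cc(C)cc(-c2c(-c3ccnc(-c4ccc(C(C)=O)cc4)c3)cnn2CC#N)c1` belongs to a small set of three compounds sharing one core and tested in a functional assay on U-251 cells (Homo sapiens) for cytotoxicity, read by sulforhodamine B assay, with a stated time of 48 h, tested at 0.01 uM; on this read-out higher numbers stand for a weaker effect at the one concentration tested and lower numbers for a stronger effect. Compound 1 gives 89%, the lowest of the three numbers. Its nearest neighbour is compound 3 `Cc1cc(O)cc(-c2nn(CC#N)cc2-c2ccnc(-c3ccc(N(C)C)cc3)c2)c1`, which gives 94%, a gap within the scatter; furthest is compound 2 `COc1cc(C)cc(-c2nn(CC#N)cc2-c2ccnc(-c3ccc(N(C)C)cc3)c2)c1`, which gives 105%, a gap beyond the scatter. For the measured compounds named here, the only single-point step among the measured compounds is a number 11 percentage points lower from compound 2 to compound 3 (beyond the scatter), with hydrogen in place of methyl on an oxygen on an aromatic ring; it says nothing about the change now considered.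

Compound 4 `COc1cc(C)cc(-c2c(-c3ccnc(-c4ccc(N(C)C)cc4)c3)cnn2CC#N)c1` differs from compound 1 by dimethylamino in place of acetyl on an aromatic carbon, on an aromatic carbon of a six-membered aromatic ring of carbon only. Going by the values given here, no measured step covers this exchange. Compounds 2 and 3 both carry the dimethylamino group, yet they differ from compound 1 in more than one place, so their numbers only hint that such compounds sit somewhat higher. Compound 4 is therefore expected to move by a number 7 percentage points higher from compound 1 to compound 4 (within the scatter) from compound 1, a shift within the scatter. Compound 4 is estimated at 96%, in a range from 82% to 110%.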

Compound 4, a percentage reported as activity, at one concentration (the size of the read-out at that concentration, not a potency): 41%
For compound 4 the middle estimate is 55 percentage points above the measured one; measured number below the stated range.
By their numbers in this assay, from the lowest: compound 4; then compounds 1 and 3 (each within the scatter of the next); then compound 2.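

Swapping acetyl for dimethylamino on an aromatic carbon of a six-membered aromatic ring of carbon only, para to a large group, gives a number 48 percentage points lower from compound 1 to compound 4 (beyond the scatter) in this assay. This is the first step shown at this position, and it shows that the read-out responds strongly to what sits there, even though the two groups count the same number of heavy atoms, hydrogen-bond donors and hydrogen-bond acceptors. Nothing available accounts for the size of the step.

As far as these compounds go, it remains open whether the step is specific to dimethylamino or would also appear with a plain amine, a morpholine ring or a carboxylic acid at this place. A single step also leaves open how the exchange would read at other concentrations.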